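The compounds below may be only part of what the source reports. "The series", "measured", "known", "first", "only" and "open" are said of these compounds alone.

Three measured compounds share one core and differ only in the group attached to it. Compound 1 `COc1ccc(-c2cc(-c3ccc(S(=O)(=O)N(C)C)cc3)cnc2N)cn1` carries a dimethylsulfamoyl group; compound 2 `COc1ccc(-c2cc(-c3ccc4cnn(C)c4c3)cnc2N)cn1` and compound 3 `COc1ccc(-c2cc(-c3cccc(C(N)=O)c3)cnc2N)cn1` carry other groups in that position. In a physicochemical assay for solubility, read by nephelometry, measured as kinetic solubility, at pH 2 (a higher number here means a more soluble compound, a lower number a less soluble compound), compound 1 gives > 100 ug/mL, which is a limit of the assay rather than a number. Compound 2 likewise gives > 100 ug/mL, again a limit. Compound 3 also gives > 100 ug/mL, once more a limit. Within the data shown here, all three measured values therefore share (the limit of > 100 ug/mL in this assay, at which 3 of the 3 values shown sit), so no step between measured compounds can be sized, and compound 1 stands at the same limit as the other two.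

Compound 4 `CNC(=O)c1ccc(-c2cnc(N)c(-c3ccc(OC)nc3)c2)cc1` is not yet measured. It differs from compound 1 in one place: methylcarbamoyl in place of dimethylsulfamoyl on an aromatic carbon. Because every measured value rests at the limit of > 100 ug/mL in this assay, at which 3 of the 3 values shown sit, there is no room in which a change could show, and the change is expected to be none beyond the scatter, so that a step that the limit leaves unreadable from compound 1 to compound 4 is the expected step. Compound 4 is expected to give about 150 ug/mL, somewhere between 80 ug/mL and 300 ug/mL, most likely reported again as a limit.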

Compound 4, solubility: 50 ug/mL
The estimate for compound 4 lay 3.0-fold (0.48 log units) above the measured number; measured number outside the range, below it.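

In this assay, compound 4 gives 50 ug/mL, so this position can yield a readable number. Methylcarbamoyl in place of dimethylsulfamoyl, para to a large group, gives an at least 2.0-fold lower number from compound 1 to compound 4 (0.30 log units; that floor lies within the scatter); the true step may be larger, but this floor alone does not separate the change from the ordinary spread of repeat measurements. Steps among the compounds held at the limit cannot be read, and compound 4 is the only compound shown that stands apart from it: the limit of > 100 ug/mL in this assay, at which 3 of the 4 values shown sit.

The compounds shown leave open how far the true value of compound 1 lies from that of compound 4. They also leave open what a dimethylcarbamoyl group or a carboxylic acid on the same aromatic carbon would give in this assay.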